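This account rests on a few compounds, and the source may have more. Where it says the series, first, only, none or still open, it means among the compounds named here.

In an ADME assay on Ava5 cells (Homo sapiens) for cytotoxicity (on this read-out higher numbers stand for lower toxicity in this test and lower numbers for higher toxicity in this test), compound 1 `NC(=S)Nc1cccc(OCCCCCOc2ccc(F)cc2)c1` gives 5000 nM. Compound 2 `NC(=S)Nc1cccc(OCCCCCOc2ccc(-c3ccccc3)cc2)c1` reaches only the limit of this assay, > 50000 nM, not a number. The step of an at least 10-fold higher number from compound 1 to compound 2 (1.00 log units; beyond the scatter) therefore has no known full size, as it runs into (the limit of > 50000 nM in this assay, at which 1 of the 2 values shown sits); compound 2 stands at the higher end of the two values shown, as a limit rather than a value. Compound 3 `NC(=S)Nc1cccc(OCCCCCOc2ccc(-c3cccs3)cc2)c1` differs from compound 2 by thiophen-2-yl in place of phenyl on an aromatic carbon. Within the data shown here, the single measured step exchanged fluoro for phenyl at that aromatic carbon; no measured step exchanges one aromatic ring for another, so the measured step bears on this change only by setting the starting point at the limit. The expected step from compound 2 to compound 3 in this assay is a number no higher from compound 2 to compound 3 (the limit leaves the size open), within the scatter. Compound 3 is estimated at 50000 nM, with a range from 18000 nM to 140000 nM, and a fair chance that this assay again reports only a limit.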

Compound 3, half-maximal cytotoxic concentration: > 50000 nM
Compound 3 gave a limit, no number; the forecaster's own chance of this, stated with the estimate: 55%; the middle value lies on the limit itself.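

In this assay, replacing fluoro at this position, para to a large group, with thiophen-2-yl gives an at least 10-fold higher number from compound 1 to compound 3 (1.00 log units; beyond the scatter), so among the compounds shown the higher number does not depend on a six-membered aromatic ring of carbon only. A five-membered aromatic ring with a sulfur atom serves here as well as phenyl does, as far as the read-out can show. Compound 3 is reported only as a limit, like compound 2, so the step between them cannot be read and no order of the two rings follows: the limit of > 50000 nM in this assay, at which 2 of the 3 values shown sit.

As far as these compounds go, the true size of the rise for either ring remains open, as does any difference between them. Also open, from the compounds shown here alone, is whether methoxy, an amine or a carboxylic acid at this position would stay with fluoro or reach the limit with the two aromatic rings.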